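Cyclobutyl amine series: dimethylamino analogue of compound 2

This account rests on a few compounds, and the source may have more. Where it says the series, first, only, none or still open, it means among the compounds named here.

Measured to date:
compound 1, `CN(C)[C@H]1C[C@H](c2c[nH]c3ccc(CC(N)=O)cc32)C1`: 724 nM in an assay on CHO-K1 cells for binding affinity to 5-hydroxytryptamine receptor 1D (Homo sapiens); on this read-out higher numbers stand for weaker inhibition and lower numbers for stronger inhibition
compound 2, `N[C@H]1C[C@H](c2c[nH]c3ccc(Oc4ccccc4)cc32)C1`: 14.5 nM in this assay

Among the measured compounds shown here, compound 2 holds the lowest of the two numbers; the only other number, that of compound 1, lies far above it, well beyond the scatter. Compound 3, `CN(C)[C@H]1C[C@H](c2c[nH]c3ccc(Oc4ccccc4)cc32)C1`, is not yet measured. It differs from compound 2 by dimethylamino in place of amino on a saturated ring carbon. For the measured compounds named here, no measured pair isolates this change: compound 1 also carries dimethylamino but differs from compound 2 in another place as well, so its number cannot be read as a step. Expected for this change is a small step, either direction or none beyond the scatter, giving a 1.4-fold higher number from compound 2 to compound 3 (0.14 log units; within the scatter). Compound 3 is therefore estimated at 20 nM, in the range 5 nM to 80 nM.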

Compound 3, half-maximal inhibitory concentration: 64.6 nM
For compound 3 the middle estimate is 3.2-fold (0.51 log units) below the measured one; the range from low to high includes it.
By their numbers in this assay, from the lowest: compound 2; then compound 3; then compound 1.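

In this assay, dimethylamino in place of amino on a saturated ring carbon gives a 4.5-fold higher number from compound 2 to compound 3 (0.65 log units; beyond the scatter), so this position responds to the change, and the amino form holds the lower number. With dimethylamino held fixed, phenoxy in place of carbamoylmethyl on an aromatic carbon gives an 11-fold lower number from compound 1 to compound 3 (1.05 log units; beyond the scatter). Nothing at hand accounts for either step.

As far as these compounds go, whether the amino to dimethylamino step holds with carbamoylmethyl on the aromatic carbon stays open. Also open, from the compounds shown here alone, is how methylamino or pyrrolidinyl would read on the same saturated ring carbon.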